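A few compounds are considered here, and "the series" means these few. Any claim that something is new, unique, unknown or untested is made for them only; others in the source may bear on it.

In a functional assay on the whole organism with Rattus norvegicus as the target (on this read-out lower numbers stand for an effect already at smaller amounts and higher numbers for an effect only at larger amounts of compound), compound 1 `CCNc1cccc(NC(=O)C(=O)OCC)c1C#N` gives 0.03 mg/kg and compound 2 `CCOC(=O)C(=O)Nc1cccc(OC(C)C)c1C#N` gives 1 mg/kg, so compound 2 holds the higher of the two numbers. Compound 3 `CCOC(=O)C(=O)Nc1cccc(F)c1C#N` keeps the shared core and alters one group of compound 2: fluoro in place of isopropoxy on an aromatic carbon, ortho to a cyano group (fluoro in place of isopropoxy on an aromatic carbon). Among the measured compounds shown here, only one measured step bears on this change: a 33-fold higher number from compound 1 to compound 2 (1.52 log units; beyond the scatter), a large step beyond the scatter, with isopropoxy in place of ethylamino on an aromatic carbon. It shows that a swap of a single group on the core can move the number a long way. For the measured compounds named here, no measured compound carries fluoro, however, so the direction of the new step remains uncertain. Compound 2 stands at the high end with 1 mg/kg, so a move towards a lower number in this assay seems more likely than a further rise, though probably a smaller move than the one measured. The expected change is a 3.3-fold lower number from compound 2 to compound 3 (0.52 log units; beyond the scatter) in this estimate. For compound 3 the estimated value is 0.3 mg/kg, with an expected range from 0.06 mg/kg to 1.5 mg/kg at its ends.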

Compound 3, dose for half-maximal effect: 59 mg/kg
The estimate for compound 3 lay 200-fold (2.29 log units) below the measured number; the whole stated range lies below it.
By their numbers in this assay, from the lowest: compound 1; then compound 2; then compound 3.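

In this assay the place ortho to a cyano group proves far more sensitive than the first pair alone could show: the new step is a 59-fold higher number from compound 2 to compound 3 (1.77 log units; beyond the scatter) and it carries the rise further, where fluoro in place of isopropoxy might have reversed it. Taken from ethylamino to fluoro, the same place spans a 2000-fold higher number from compound 1 to compound 3 (3.29 log units; beyond the scatter) and thus covers a much wider range than the earlier step showed. Fluoro, with fewer heavy atoms than isopropoxy and no hydrogen-bond acceptor, stands with the highest number of the three compounds.

The data at hand give no measured reason for these large steps. As far as these compounds go, it remains open whether the low number of compound 1 would persist with a plain amine, a methylamino group or a longer chain such as propylamino, and whether a hydroxyl group or a methoxy group at this place would fall nearer to compound 1 or to compound 3.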